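The source may hold more compounds than are shown below. What is called first, only, known or untested is meant among the compounds shown, and "the series" means these compounds.

Working notes on the series, anchored on compound 1 (`O=C(CCCCC(S)CCS)Nc1ccccc1`). In a functional assay on KB cells (Homo sapiens) for inhibition, read by MTT assay, with a stated time of 24 h, tested at 0.1 ug/mL (on this read-out lower numbers stand for less inhibition of growth and higher numbers for more inhibition of growth at the one concentration tested), compound 1 gives 9.49% and sits within the scatter of compound 3 (`O=C(CCCCC(S)CCS)Nc1ccc(OC(F)(F)F)cc1`), which gives 7.27% on the same scale. Compound 2 (`O=C(CCCCC(S)CCS)Nc1ccccc1Cl`) is reported as "not active" (no number reported) without a number, so it fixes no step size. Compound 4 (`Cc1cccc(NC(=O)CCCCC(S)CCS)c1`) differs from compound 1 by methyl in place of hydrogen on an aromatic carbon in a single place: methyl in place of hydrogen on an aromatic carbon, meta to a large group.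

Within the data shown here, the one measured step that bears on this change, a number 2.2 percentage points lower from compound 1 to compound 3 (within the scatter) for trifluoromethoxy in place of hydrogen on an aromatic carbon, is small. It is a single precedent with a different group, so no step beyond the scatter is expected in this assay and no direction is assigned. The expected a number 1 percentage points lower from compound 1 to compound 4 (within the scatter) stays within the scatter. For compound 4 the estimated value is 8.5% with an expected range from 2% to 17% in this read-out.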

Compound 4, percent growth inhibition at one concentration: 5.75%
Estimate against measurement, compound 4: 2.8 percentage points above; low and high end bracket the measured number.
By their numbers in this assay, from the lowest: compounds 4, 3 and 1 (each within the scatter of the next).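

In this assay, methyl in place of hydrogen on an aromatic carbon, meta to a large group, gives a number 3.7 percentage points lower from compound 1 to compound 4 (within the scatter), so this position now has a reading of its own and the change stays within the scatter. The trifluoromethoxy change gave a number 2.2 percentage points lower from compound 1 to compound 3 (within the scatter), also within the scatter, so neither of the two replacements with a number separates from the parent, and the result gives no direction for methyl at this position. Nothing available here accounts for the result.

From the compounds shown here alone, whether an amine or a carboxylic acid on this same aromatic carbon would give a step beyond the scatter remains open. Also open, going by these compounds, is how a longer chain in place of the one in the shared core would read at the one concentration tested.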